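Tolerated concentration on the way to compound 4

The source may hold more compounds than are shown below. What is called first, only, known or untested is meant among the compounds shown, and "the series" means these compounds.

Values from an ADME assay on MT4 cells (Homo sapiens) for cytotoxicity, read by MTT assay, with a stated time of 5 days; a higher number here means that more compound is tolerated, a lower number that less compound is tolerated:
- compound 1 `Cc1ccc(-c2cnc(Nc3ccc(C#N)cc3)nc2Oc2c(C)cc(C#N)cc2C)cc1`: 26100 nM
- compound 2 `Cc1cc(C#N)cc(C)c1Oc1nc(Nc2ccc(C#N)cc2)ncc1-c1cccc2ccccc12`: > 267000 nM, a limit of the assay
- compound 3 `Cc1cc(C#N)cc(C)c1Oc1nc(Nc2ccc(C#N)cc2)ncc1-c1cncnc1`: > 298000 nM, a limit of the assay

Compound 3 stands at the upper edge of what this assay reports; its value is a limit, not a number, as the limit of > 298000 nM in this assay, at which 1 of the 3 values shown sits, records. Compound 2 likewise sits at a limit, (the limit of > 267000 nM in this assay, at which 1 of the 3 values shown sits). Only compound 1 gives a measured number, and from it both measured steps run upward: an at least 10-fold higher number from compound 1 to compound 2 (1.00 log units; beyond the scatter) and an at least 11-fold higher number from compound 1 to compound 3 (1.05 log units; beyond the scatter). The step between the two limits, a step that the two limits leave unreadable from compound 2 to compound 3, cannot be sized.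

Compound 4 `Cc1cc(C#N)cc(C)c1Oc1nc(Nc2ccc(C#N)cc2)ncc1-c1cccs1` differs from compound 3 in one place: thiophen-2-yl in place of pyrimidin-5-yl on an aromatic carbon. The group entering is a five-membered aromatic ring with one hetero atom, between the 4-methylphenyl of compound 1 and the pyrimidin-5-yl of compound 3 in kind. The steps bearing on it, from compound 1 to compound 2 and from compound 1 to compound 3, show that replacing 4-methylphenyl raised the tolerated concentration at least modestly; whether thiophen-2-yl keeps compound 4 at the limit is open.

For compound 4 a value somewhat below the limit is expected, 100000 nM, within 30000 nM to 300000 nM. The step from compound 3 is thus estimated as an at least 2.9-fold lower number from compound 3 to compound 4 (0.47 log units; beyond the scatter), with a fair chance that this assay again reports only a limit.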

Compound 4, half-maximal cytotoxic concentration: 6430 nM
For compound 4 the middle estimate is 16-fold (1.19 log units) above the measured one; the measured number lies below the stated range.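

In this assay the aromatic carbon para to the (4-cyanophenyl)amino group is no longer a place where every replacement of 4-methylphenyl raises the tolerated concentration: thiophen-2-yl gives a 4.1-fold lower number from compound 1 to compound 4 (0.61 log units; beyond the scatter), the only downward step from compound 1 among the compounds shown. The contrast with the other two replacements is larger, with an at least 46-fold lower number from compound 3 to compound 4 (1.66 log units; beyond the scatter) and an at least 41-fold lower number from compound 2 to compound 4 (1.61 log units; beyond the scatter), so the outcome at this position depends on which aromatic ring enters and not merely on the loss of 4-methylphenyl. Each of those two steps starts from a limit of the assay and not from a number, for compound 2 as for compound 3, and no measurement shown gives a reason for the fall with thiophen-2-yl.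

On these data alone, whether the lower tolerated concentration belongs to thiophen-2-yl alone or extends to other five-membered aromatic rings, such as thiophen-3-yl, furan-2-yl or thiazol-2-yl, remains open. As far as these compounds go, it is equally open where a non-aromatic group at this carbon, such as morpholine or a dimethylamino group, would fall relative to compound 1 and compound 4.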